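Swapping Fluoro for Methyl on the Benzyl Group

This account rests on a few compounds, and the source may have more. Where it says the series, first, only, none or still open, it means among the compounds named here.

Measured so far in a functional assay on HeLa cells (Homo sapiens) for cytotoxicity, read by MTT assay, with a stated time of 72 h; a lower number here means a stronger inhibitor, a higher number a weaker inhibitor

Compound 1 `Nn1c(SCc2ccccc2[N+](=O)[O-])nnc1-c1c[nH]c2ccccc12` gives 2520 nM
Compound 2 `Nn1c(SCc2cccc([N+](=O)[O-])c2)nnc1-c1c[nH]c2ccccc12` gives 400 nM
Compound 3 `Nn1c(SCc2ccc(F)cc2)nnc1-c1c[nH]c2ccccc12` gives 290 nM

Compound 3 sits at the low end of this small set. It lies within the scatter of compound 2 and beyond the scatter from compound 1, which reads higher. Compound 4 `Cc1ccc(CSc2nnc(-c3c[nH]c4ccccc34)n2N)cc1` keeps the shared core and changes one group: methyl in place of fluoro on an aromatic carbon, with methyl in place of fluoro on an aromatic carbon, turning 4-fluorobenzyl into 4-methylbenzyl. Within the data shown here, no pair of measured compounds differs in one place, so the data offer no direct guide to the size of this step. Starting from compound 3 at 290 nM, no step beyond the scatter is expected in this assay, with a slight lean toward a higher number. The expected step is a 1.4-fold higher number from compound 3 to compound 4 (0.14 log units; within the scatter) and this remains an estimate. The estimate for compound 4 is 400 nM, expected to fall from 150 nM to 1100 nM once measured.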

Compound 4, half-maximal inhibitory concentration: 5380 nM
Beside the measured number, compound 4's estimate is 13-fold (1.13 log units) below it, outside the stated range (above it).
By their numbers in this assay, from the lowest: compounds 3 and 2 (each within the scatter of the next); then compound 1; then compound 4.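

In this assay, turning 4-fluorobenzyl into 4-methylbenzyl gives a 19-fold higher number from compound 3 to compound 4 (1.27 log units; beyond the scatter) and so shows that this position on the benzyl group is sensitive to what it carries, even when one heavy atom simply replaces another. Among these compounds, this is the only step in the set that differs in one place, and it is the first direct measure of change at this position. The exchange alters no ring, no net charge and no hydrogen-bond count, and no measurement available here accounts for the size of the step.

The compounds shown leave open whether the gap reflects something favourable about fluoro or something unfavourable about methyl. A chloro or methoxy group in that place, or an unsubstituted benzyl, would help separate the two readings.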